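Compound 2 to compound 4: one group grows

The source may hold more compounds than are shown below. What is called first, only, known or untested is meant among the compounds shown, and "the series" means these compounds.

Measured so far in a physicochemical assay for solubility, in phosphate buffer, at pH 7.4; a lower number here means a less soluble compound, a higher number a more soluble compound:
compound 1 `CC(=O)N[C@@H]1CCC[C@H](C(=O)Nc2cc(-c3cnn4c3CCCC4)ccn2)C1` gives 730000 nM
compound 2 `CC(=O)N[C@@H]1CCC[C@H](C(=O)Nc2cc(-c3cnc4n3CCC4)c(Cl)cn2)C1` gives 490000 nM
compound 3 `CC(=O)N[C@@H]1CCC[C@H](C(=O)Nc2cc(-c3cnn4c3CC(C)(C)CC4)ccn2)C1` gives 640000 nM

Compound 2 lies within the usual scatter of both compound 1 and compound 3, so these three numbers cannot be told apart. Compound 4 `CC(=O)N[C@@H]1CCC[C@H](C(=O)Nc2cc(-c3cnn4c3CC(C)(C)C4)c(Cl)cn2)C1` has not yet been measured. It differs from compound 2 in one group a group of 10 heavy atoms (8 carbon, 2 nitrogen; one five-membered non-aromatic ring with 1 hetero atom, one five-membered aromatic ring with 2 hetero atoms) in place of a group of 8 heavy atoms (6 carbon, 2 nitrogen; one five-membered non-aromatic ring with 1 hetero atom, one five-membered aromatic ring with 2 hetero atoms), on an aromatic carbon on an aromatic carbon, ortho to a chloro group. Going by the values given here, no measured pair shows this change directly, so the evidence is thin. With the three measured values so close together, no step beyond the scatter is expected. The estimated change is a 1.1-fold lower number from compound 2 to compound 4 (0.05 log units; within the scatter) and it stays within that scatter. Compound 4 is estimated at 440000 nM with a range from 200000 nM to 800000 nM as the expected span.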

Compound 4, solubility: 150000 nM
The estimate for compound 4 lay 2.9-fold (0.47 log units) above the measured number, outside the stated range (below it).
By their numbers in this assay, from the lowest: compound 4; then compounds 2, 3 and 1 (each within the scatter of the next).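

In this assay, going by these compounds alone, the group of 10 heavy atoms in place of the group of 8, on an aromatic carbon ortho to a chloro group, gives a 3.3-fold lower number from compound 2 to compound 4 (0.51 log units; beyond the scatter) and is the first step here beyond the scatter. This position therefore responds to a change of group, even though both groups have the same ring types and the same counts of hydrogen-bond donors and acceptors. From the compounds shown here alone, whether the exchange acts alike without the chloro group stays open, as does the effect of a group carrying an amine or a carboxylic acid here. No measurement at hand gives a reason for the drop.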